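The source may report more compounds than this note shows. Statements on the series, on what has been measured and on what is new or still open speak of the compounds shown alone.

Working notes on the series, values in a functional assay on KG-1 cells (Homo sapiens) for cytotoxicity, read by luminescence and CellTiter-Glo, with a stated time of 3 days; on this read-out higher numbers stand for weaker inhibition and lower numbers for stronger inhibition:

- compound 1 `O=C(Nc1ccc(OC(F)(F)F)cc1)c1cc(F)ccc1O`: 780 nM
- compound 2 `O=C(Nc1ccc(OC(F)(F)F)c(Cl)c1)c1cc(F)ccc1O`: 370 nM
- compound 3 `O=C(Nc1ccc(Cl)c(Cl)c1)c1cc(F)ccc1O`: 760 nM

Of these three, compound 2 carries the lowest number, at 370 nM, and both of its neighbours sit higher by more than the scatter. The next compound to consider is compound 4 `O=C(Nc1ccc(OC(F)(F)F)c(Cl)c1)c1cc(Cl)ccc1O`, which differs from compound 2 in one place: chloro in place of fluoro on an aromatic carbon. In words, this is chloro in place of fluoro on an aromatic carbon.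

For the measured compounds named here, no measured step changes that fluoro, which is common to compounds 1, 2 and 3, so the data give no direct precedent. Going by the values given here, two steps bear on it only indirectly. The first, a 2.1-fold lower number from compound 1 to compound 2 (0.32 log units; beyond the scatter), is chloro in place of hydrogen on an aromatic carbon. The second, a 2.1-fold higher number from compound 2 to compound 3 (0.31 log units; beyond the scatter), is chloro in place of trifluoromethoxy. Both are modest and both occur elsewhere in the molecule. They suggest that single substituent swaps in this series move this assay only slightly. The gain seen with chloro in a 2.1-fold lower number from compound 1 to compound 2 (0.32 log units; beyond the scatter) gives a weak lean towards a lower number.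

The estimate means a 1.4-fold lower number from compound 2 to compound 4 (0.15 log units; within the scatter), an expected small step no larger than those measured. For compound 4 the expected value is 260 nM, with an estimated range of 110 nM to 600 nM.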

Compound 4, half-maximal inhibitory concentration: 460 nM
The estimate for compound 4 lay 1.8-fold (0.25 log units) below the measured number; measured number inside the range.
By their numbers in this assay, from the lowest: compounds 2, 4, 3 and 1 (each within the scatter of the next, the first and the last beyond it).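

Working notes on this position: in this assay, chloro in place of fluoro on the aromatic carbon para to a hydroxy group gives a 1.2-fold higher number from compound 2 to compound 4 (0.09 log units; within the scatter), the first measured change at this carbon. Unlike the two earlier steps, both beyond the scatter and both elsewhere in the molecule, this one lies within it, so on this read-out the two halogens cannot be told apart here, at least with the chloro and trifluoromethoxy substitution of compound 2 on the other ring. No measurement at hand speaks to why the two halogens read alike.

As far as these compounds go, it remains open how hydrogen, a methoxy group, an amine or a carboxylic acid on this carbon would read, and therefore whether the position is insensitive in general or only to an exchange of one halogen for another. From the compounds shown here alone, it also remains open whether chloro in place of fluoro reads the same way in the setting of compound 3, with chloro in place of trifluoromethoxy, or in that of compound 1, with hydrogen in place of the chloro.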